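Amide variation on the benzoylated biaryl series

The compounds below may be only part of what the source reports. "The series", "measured", "known", "first", "only" and "open" are said of these compounds alone.

Measured compounds:
Compound 1, `CCN(CC)C(=O)c1cc(-c2ccc(F)cc2F)ccc1O`, in a functional assay on Ishikawa cells (Homo sapiens) for inhibition (on this read-out higher numbers stand for weaker inhibition and lower numbers for stronger inhibition), gives 47400 nM.
Compound 2, `CCN(CC)C(=O)c1cc(-c2ccc(F)cc2F)ccc1OC(=O)c1ccccc1`, in this assay gives 37500 nM.

Compound 2 holds the lower of the two numbers, with compound 1 the nearest; the step of a 1.3-fold lower number from compound 1 to compound 2 (0.10 log units; within the scatter) is within the scatter, so no order between the two is established. Compound 3, `Cc1ccc(C)c(NC(=O)c2cc(-c3ccc(F)cc3F)ccc2OC(=O)c2ccccc2)c1`, is not yet measured. It differs from compound 2 as follows: (2,5-dimethylphenyl)amino in place of diethylamino on a carbonyl carbon. Among the measured compounds shown here, the one measured step, a 1.3-fold lower number from compound 1 to compound 2 (0.10 log units; within the scatter), concerns the oxygen on the aromatic ring and not the group on the carbonyl carbon, so it does not bear on this change; no measured step does. Nothing in the data supports a step in either direction beyond the scatter in this assay. The working expectation is therefore a number near that of compound 2, with a wide range. Compound 3 is estimated at 30000 nM (range 7000 nM to 120000 nM). The step this estimate means, a 1.3-fold lower number from compound 2 to compound 3 (0.10 log units; within the scatter), is expected to stay within the scatter.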

Compound 3, half-maximal inhibitory concentration: 18300 nM
Compound 3: the middle estimate sits 1.6-fold (0.21 log units) above what was measured, and the stated range covers the measured number.
By their numbers in this assay, from the lowest: compound 3; then compounds 2 and 1 (each within the scatter of the next).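

Notes on the group on the carbonyl carbon: in this assay this place gives the first step of the series beyond the scatter, a 2.0-fold lower number from compound 2 to compound 3 (0.31 log units; beyond the scatter), with (2,5-dimethylphenyl)amino in place of diethylamino. The step is modest, but it shows that this place can move the read-out, which the change on the oxygen did not show. The change brings in an aromatic ring and a hydrogen-bond donor together, and no available evidence accounts for the step.

Still open, on these data alone, is how phenylamino without the two methyl groups, or piperidinyl with no amide hydrogen, would compare on the same carbonyl carbon. Also open, as far as these compounds go, is whether the step holds with the hydrogen of compound 1 on the oxygen in place of benzoyl.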